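The source may hold more compounds than are shown below. What is called first, only, known or untested is meant among the compounds shown, and "the series" means these compounds.

Going by the values given here, compound 1 `O=C(/C=C/c1ccc(O)c(O)c1)OCc1c(-c2ccccc2)no[n+]1[O-]` is the only compound in this set with a measured number. In a functional assay on SKBR cells (Homo sapiens) for cytotoxicity, read by resazurin assay, with a stated time of 72 h (a higher number here means a weaker inhibitor, a lower number a stronger inhibitor), compound 1 gives 700 nM. Compound 2 `COc1cc(/C=C/C(=O)OCCOc2no[n+]([O-])c2S(=O)(=O)c2ccccc2)ccc1O` also belongs to the set. In this assay compound 2 is reported only as a limit of the assay, > 50000 nM. Among the compounds with values here, of the two values shown, compound 1 therefore holds the single actual number, the other entry being a limit (the limit of > 50000 nM in this assay, at which 1 of the 2 values shown sits). Compound 3 `COc1cc(/C=C/C(=O)OCc2c(-c3ccccc3)no[n+]2[O-])ccc1O` has not yet been measured. It differs from compound 1 by a single change, (methyl in place of hydrogen on an oxygen on an aromatic ring). Within the data shown here, no pair of measured compounds differs in just one place, so no measured step shows how such a change behaves in this assay. A modest weakening beyond the usual scatter is expected, with an estimated step of a 2.9-fold higher number from compound 1 to compound 3 (0.46 log units; beyond the scatter). Compound 3 is thus expected to give 2000 nM in this assay, within a range from 700 nM to 8000 nM.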

Compound 3, half-maximal inhibitory concentration: 4980 nM
Compound 3: the middle estimate sits 2.5-fold (0.40 log units) below what was measured, within the range that was stated.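

In this assay, going by these compounds alone, the change from hydroxy to methoxy, which turns the 3,4-dihydroxyphenyl group of compound 1 into the 4-hydroxy-3-methoxyphenyl group, brings a 7.1-fold higher number from compound 1 to compound 3 (0.85 log units; beyond the scatter) and so gives the only measured step at this place. It shows that methyl on this oxygen weakens the compound beyond the usual scatter, although compound 3 still gives an actual number and not a limit. Nothing given here accounts for the size of this step.

As far as these compounds go, how an ethyl group on this oxygen, or an amine in place of this hydroxy, would behave stays open. Within the data shown here, also open is whether the same change on the other hydroxy, the one kept in compound 3, would give a step of similar size.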